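The compounds below may be only part of what the source reports. "The series", "measured", "known", "first", "only" and "open" are said of these compounds alone.

Measured so far:
- compound 1, `Nc1ncnc(Oc2ccc(NC(=O)C3(C(=O)Nc4ccc(F)cc4)CC3)cc2F)c1/C=N/O`: 2.62
- compound 2, `Nc1ncnc(Oc2ccc(NC(=O)C3(C(=O)Nc4ccc(F)cc4)CC3)cc2F)c1/C=N/OC1CCCCC1`: 4.69

In a physicochemical assay for lipophilicity, using the shake flask method (on this read-out lower numbers stand for lower lipophilicity and higher numbers for higher lipophilicity), compound 2 stands highest of the two measured compounds, with compound 1 nearest and a good deal lower. Among the measured compounds shown here, the one measured step, a number 2.07 log units higher from compound 1 to compound 2 (beyond the scatter), shows how much a cyclohexyl in place of hydrogen on an oxygen raises this read-out. Compound 3, `COCCCO/N=C/c1c(N)ncnc1Oc1ccc(NC(=O)C2(C(=O)Nc3ccc(F)cc3)CC2)cc1F`, is compound 2 with one change, (3-methoxypropyl in place of cyclohexyl on an oxygen). For the measured compounds named here, the step that bears on it is the one from compound 1 to compound 2: the cyclohexyl accounts for a large rise, and the 3-methoxypropyl that replaces it is smaller, with no ring and one more hydrogen-bond acceptor, so a fall is expected, though not all the way back to compound 1. The expected step is a number 1.19 log units lower from compound 2 to compound 3 (beyond the scatter). Compound 3 is therefore estimated at 3.5, within a range from 3 to 4.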

Compound 3, partition coefficient: 3.18
Beside the measured number, compound 3's estimate is 0.32 log units above it, within the range that was stated.
By their numbers in this assay, from the lowest: compound 1; then compound 3; then compound 2.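

In this assay, putting 3-methoxypropyl in place of cyclohexyl on this oxygen moves the read-out a long way (a number 1.51 log units lower from compound 2 to compound 3 (beyond the scatter)), so the outcome here depends on which group is attached, not just on whether the hydrogen has been replaced. Measured against the hydrogen of compound 1, 3-methoxypropyl still gives a rise (a number 0.56 log units higher from compound 1 to compound 3 (beyond the scatter)), but a much smaller one than cyclohexyl gives (a number 2.07 log units higher from compound 1 to compound 2 (beyond the scatter)). No measurement at hand explains why these two groups differ.

Cyclohexyl and 3-methoxypropyl differ both in the ring and in the oxygen of the chain, so these compounds cannot separate the two features. A plain pentyl chain, made of carbon only, or a chain ending in an amine would help to tell them apart.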